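Swapping an amide-bearing ring for a bridged amine

A few compounds are considered here, and "the series" means these few. Any claim that something is new, unique, unknown or untested is made for them only; others in the source may bear on it.

Three measured compounds share one core and differ only in the amine attached to it. In a functional assay on HEK293 cells for activation of melanin-concentrating hormone receptor 1 (Rattus norvegicus), read by inositol phosphate accumulation (on this read-out lower numbers stand for an effect already at smaller amounts and higher numbers for an effect only at larger amounts of compound), compound 1 `CC1CCN(c2ccc3cc(NC(=O)CCc4ccc(C(F)(F)F)cc4)ccc3n2)C1` gives 400 nM. Compound 2 `CC(C)C(=O)NC1CCN(c2ccc3cc(NC(=O)CCc4ccc(C(F)(F)F)cc4)ccc3n2)C1` gives 90 nM in this assay, the lowest of the two single numbers; compound 3 `O=C(CCc1ccc(C(F)(F)F)cc1)Nc1ccc2nc(N3CCCC3)ccc2c1` gives 320 nM; 320 nM (2 entries) in this assay, recorded twice. Among the measured compounds shown here, the only step between neighbours that differ in one place is a 4.4-fold lower number from compound 1 to compound 2 (0.65 log units; beyond the scatter), so the ring carrying the amide goes with the lower number.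

Compound 4 `O=C(CCc1ccc(C(F)(F)F)cc1)Nc1ccc2nc(N3CC4CCC3CC4)ccc2c1` differs from compound 2 by a group of 8 heavy atoms (7 carbon, 1 nitrogen; 2 six-membered non-aromatic rings with 1 hetero atom each) in place of a group of 11 heavy atoms (8 carbon, 2 nitrogen, 1 oxygen; one five-membered non-aromatic ring with 1 hetero atom), on an aromatic carbon. Compound 4 therefore lacks the amide that compound 1 and compound 3 also lack, and both of those stand at higher numbers than compound 2. The expectation is that compound 4 moves back toward their range, with a step of a 4.4-fold higher number from compound 2 to compound 4 (0.65 log units; beyond the scatter). Compound 4 is thus estimated at 400 nM, within a range from 120 nM to 1500 nM, in this assay.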

Compound 4, half-maximal effective concentration: 190 nM
Beside the measured number, compound 4's estimate is 2.1-fold (0.32 log units) above it, and the stated range covers the measured number.
By their numbers in this assay, from the lowest: compound 2; then compound 4; then compound 1.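

At this position, next to the ring nitrogen, a lower number does not depend on the amide alone: in this assay, the group with two six-membered non-aromatic rings gives a 2.1-fold lower number from compound 1 to compound 4 (0.32 log units; beyond the scatter), although it carries no amide. The 3-((isopropylcarbonyl)amino)pyrrolidin-1-yl group still holds the lowest number of the series, as a 2.1-fold higher number from compound 2 to compound 4 (0.32 log units; beyond the scatter) shows, so removing that group together with its amide costs only a modest step when the two-ring group enters.

Going by these compounds, it remains open whether a simple amine or a carboxylic acid in place of the isopropylcarbonyl amide would keep the low number of compound 2, and whether an amide added to the two-ring group would lower the number of compound 4. Nothing measured on these compounds explains why either step arises.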